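The compounds below may be only part of what the source reports. "The series", "measured", "known", "first", "only" and "open" are said of these compounds alone.

Measured:
compound 1 `COc1cc(C)cc(-c2nn(CC#N)cc2-c2ccc(-c3cccc(C(C)=O)c3)nc2)c1`: -38%
compound 2 `Cc1cc(O)cc(-c2nn(CC#N)cc2-c2ccnc(-c3ccc(Oc4ccccc4)cc3)c2)c1`: -14%

In a functional assay on DU-145 cells (Homo sapiens) for cytotoxicity, read by sulforhodamine B assay, with a stated time of 48 h, tested at 1 uM (on this read-out lower numbers stand for a stronger effect and higher numbers for a weaker effect at the one concentration tested), compound 1 gives -38% and compound 2 gives -14%. Compound 2 stands highest of the two numbers; its nearest neighbour is compound 1, a number lower by a gap beyond the scatter.

Compound 3 `Cc1cc(O)cc(-c2nn(CC#N)cc2-c2ccnc(-c3ccc(N(C)C)cc3)c2)c1` is not yet measured. It differs from compound 2 by dimethylamino in place of phenoxy on an aromatic carbon. Within the data shown here, no step between measured compounds covers this change, so the expected step from compound 2 to compound 3 in this assay is none beyond the scatter, with wide uncertainty.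

Compound 3 is estimated at -20%, range -45% to 5%, which is the expected step of a number 6 percentage points lower from compound 2 to compound 3 (within the scatter).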

Compound 3, a percentage reported as activity, at one concentration (the size of the read-out at that concentration, not a potency): -7%
The estimate for compound 3 lay 13 percentage points below the measured number; the measured number falls inside the stated range.
By their numbers in this assay, from the lowest: compound 1; then compounds 2 and 3 (each within the scatter of the next).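

In this assay, dimethylamino in place of phenoxy on an aromatic carbon, para to a large group, gives a number 7 percentage points higher from compound 2 to compound 3 (within the scatter). This position therefore tolerates loss of the phenoxy ring with no change beyond the scatter in this read-out, and the shared hydrogen-bond acceptor count leaves open which feature of either group matters, if any. No available measurement bears on the reason for this result.

The compounds shown leave open whether a primary amine or a carboxylic acid at this carbon would keep the read-out at this level. A longer chain on the amine nitrogen also remains untested in the compounds shown.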